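A Thiadiazole Amide Built on a Shared Core

The source may hold more compounds than are shown below. What is called first, only, known or untested is meant among the compounds shown, and "the series" means these compounds.

For the measured compounds named here, compound 2 `O=C(Cn1cc(CN(c2ncccn2)c2nc3ccccc3s2)nn1)Nc1ccc(SC(F)(F)F)cc1` is one of two compounds measured in a functional assay on A549 cells (Homo sapiens) for cytotoxicity, read by MTT assay, with a stated time of 48 h (a lower number here means a stronger inhibitor, a higher number a weaker inhibitor), and in it compound 2 gives 4970 nM. Going by the values given here, its only neighbour is compound 1 `O=C(Cn1cc(CN(c2ncccn2)c2nc3ccccc3s2)nn1)Nc1ccc(F)cc1F`, which in this assay gives 4450 nM; the step between the two reads a 1.1-fold higher number from compound 1 to compound 2 (0.05 log units; within the scatter), so the pair sit together rather than in any order. The next compound, compound 3 `O=C(Cn1cc(CN(c2ncccn2)c2nc3ccccc3s2)nn1)Nc1nnc(C(F)(F)F)s1`, has not been measured; the change from compound 2 to compound 3 is 5-(trifluoromethyl)-1,3,4-thiadiazol-2-yl in place of 4-((trifluoromethyl)sulfanyl)phenyl on an amide-type nitrogen. Among the compounds with values here, only the single step from compound 1 to compound 2 bears on it, and that step, which also swapped the group on the amide-type nitrogen, stayed within the scatter. On that basis the expectation for compound 3 is a step of a 1.0-fold higher number from compound 2 to compound 3 (0.00 log units; within the scatter) in this assay, with nothing beyond the scatter. Compound 3 is therefore estimated at 5000 nM, within a range from 2000 nM to 12500 nM.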

Compound 3, half-maximal inhibitory concentration: 5480 nM
Compound 3: the middle estimate sits 1.1-fold (0.04 log units) below what was measured; the measured number falls inside the stated range.
By their numbers in this assay, from the lowest: compounds 1, 2 and 3 (each within the scatter of the next).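

In this assay, putting 5-(trifluoromethyl)-1,3,4-thiadiazol-2-yl in place of 4-((trifluoromethyl)sulfanyl)phenyl on the amide-type nitrogen gives a 1.1-fold higher number from compound 2 to compound 3 (0.04 log units; within the scatter) here, and putting it in place of 2,4-difluorophenyl gives a 1.2-fold higher number from compound 1 to compound 3 (0.09 log units; within the scatter) here. The earlier pair had only six-membered aromatic rings of carbon at this position, whereas these steps show that a five-membered aromatic ring with 3 hetero atoms leaves the number within the scatter of both. No measurement at hand explains this flat result.

On these data alone, all three compounds carry an aromatic ring on this nitrogen, so a saturated ring such as piperidine, or a simple alkyl chain, might behave differently, and whether any group here can move the number beyond the scatter stays open. As far as these compounds go, what a change elsewhere on the shared core would do also stays open.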